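This account rests on a few compounds, and the source may have more. Where it says the series, first, only, none or still open, it means among the compounds named here.

Compound 1 `COc1ccccc1C(=O)Nc1cccc(NC(=O)C2CCCCC2)c1`: in an in vitro functional assay on HEK293-A cells for antagonist activity at metabotropic glutamate receptor 5 (Rattus norvegicus), read by calcium flux (a lower number here means a stronger inhibitor, a higher number a weaker inhibitor), compound 1 gives > 30000 nM, which is a limit of the assay and not a number.
Compound 2 `O=C(Nc1cccc(NC(=O)c2cccc(Cl)c2)c1)c1cccc(F)c1`: in this assay compound 2 gives > 30000 nM, again a limit and not a number.

Compound 2 therefore stands at the limit of > 30000 nM in this assay, at which 2 of the 2 values shown sit, with no numerical value to set against compound 1. Compound 3 `O=C(Nc1cccc(NC(=O)C2CCCCC2)c1)c1cccc(Cl)c1` differs from compound 2 by cyclohexyl in place of 3-fluorophenyl on a carbonyl carbon. Going by the values given here, no step between measured compounds is available to size this change, and compound 1, which also carries a cyclohexyl group, likewise sits at the limit. No step beyond the scatter is expected in this assay, in either direction. Compound 3 is expected to give about 40000 nM, between 15000 nM and 120000 nM. The expected step is a step that the limit leaves unreadable from compound 2 to compound 3.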

Compound 3, half-maximal inhibitory concentration: > 30000 nM
Compound 3: only a limit was reported; the forecaster's own chance of this, stated with the estimate: 85%; the middle value lies beyond the limit too.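

Compound 3 gives > 30000 nM in this assay, again a limit and not a number. The steps to it from compound 1 and compound 2 cannot be read. The compounds shown leave open which groups on the carbonyl carbons would give a measurable inhibition.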